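The source may hold more compounds than are shown below. What is called first, only, known or untested is meant among the compounds shown, and "the series" means these compounds.

Measured so far in a functional assay on cells (Cancer cell lines, Homo sapiens) for inhibition; on this read-out higher numbers stand for weaker inhibition of growth and lower numbers for stronger inhibition of growth:

compound 1 `N#CSc1c(-c2ccccc2)nc2sc(Cc3ccccc3)nn12` — 4400 nM
compound 2 `COc1ccc(-c2nc3sc(Cc4ccccc4)nn3c2SC#N)cc1` — 3900 nM
compound 3 `O=Cc1c(-c2ccc([N+](=O)[O-])cc2)nc2sc(Cc3ccccc3)nn12` — 2900 nM

Compound 3 gives the lowest of the three numbers in this assay, but its gaps to compound 2 and to compound 1 are both within the scatter, so no order among the three can be read from these values. Among the measured compounds shown here, the single one-place step on record, a 1.1-fold lower number from compound 1 to compound 2 (0.05 log units; within the scatter), lies on the phenyl ring and is within the scatter. Compound 3 differs from compounds 1 and 2 in two places at once, so their values show only that all three sit in the same range.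

Compound 4 `O=[N+]([O-])c1ccc(-c2nc3sc(Cc4ccccc4)nn3c2Br)cc1` is the next member. The change from compound 3 is bromo in place of formyl on an aromatic carbon. For the measured compounds named here, no measured step touches this position or this pair of groups; the only recorded step is elsewhere and flat. On that basis no step beyond the scatter is expected, and a 1.0-fold higher number from compound 3 to compound 4 (0.01 log units; within the scatter) is the estimated change. Compound 4 is therefore expected to give about 3000 nM in this assay, with a range of 1100 nM to 8500 nM.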

Compound 4, concentration for 50% growth inhibition: 3400 nM
Estimate against measurement, compound 4: 1.1-fold (0.05 log units) below; low and high end bracket the measured number.
By their numbers in this assay, from the lowest: compounds 3, 4, 2 and 1 (each within the scatter of the next).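

Bromo in place of formyl on this aromatic carbon gives a 1.2-fold higher number from compound 3 to compound 4 (0.07 log units; within the scatter) in this assay as the first one-place step on record at this position. With the rest of compound 3 held fixed, the 2 heavy atoms of formyl, with its double bond and hydrogen-bond acceptor, give way to a single bromine atom without a step beyond the scatter. No measurement at hand offers a reason for this flat step.

Among the compounds shown here, only formyl and bromo can be compared at this position so far, so an amine, a carboxylic acid or a longer chain on this carbon could still give a step beyond the scatter. On these data alone, it also remains open whether bromo and formyl stay level when the nitro group on the phenyl ring gives way to methoxy or hydrogen.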